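From trifluoromethyl to fluoro in a cell tolerance test

The source may hold more compounds than are shown below. What is called first, only, known or untested is meant among the compounds shown, and "the series" means these compounds.

Of the compounds shown here, two built on one shared core have been tested so far. In an ADME assay on U2OS cells (Homo sapiens) for cytotoxicity (a lower number here means that less compound is tolerated, a higher number that more compound is tolerated), compound 1 (`CC(C)(O)c1cc2c(-c3ccsc3)nccc2[nH]1`) gives 199000 nM and compound 2 (`CC(C)(O)c1cc2c(-c3ccc(C(F)(F)F)cc3)nccc2[nH]1`) gives 72300 nM as its reading. Compound 2 therefore holds the lower of the two numbers, which makes it the less tolerated of the pair, and the gap between them lies beyond the usual scatter.

The next compound to be tested is compound 3 (`CC(C)(O)c1cc2c(-c3ccc(F)cc3)nccc2[nH]1`). It differs from compound 2 in a single place, with fluoro in place of trifluoromethyl on an aromatic carbon. Among the measured compounds shown here, no measured pair yet shows what a single change of this kind does in this assay, so any forecast rests on thin evidence. For the measured compounds named here, with compound 2 at 72300 nM and compound 1 at 199000 nM as the only guides, a small upward move that stays within the scatter seems most likely. The expected change is a 1.7-fold higher number from compound 2 to compound 3 (0.22 log units; within the scatter) on this estimate. For compound 3 the estimated value is 120000 nM with an expected range from 55000 nM to 260000 nM in this test.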

Compound 3, half-maximal cytotoxic concentration: 93600 nM
Estimate against measurement, compound 3: 1.3-fold (0.11 log units) above; the range from low to high includes it.
By their numbers in this assay, from the lowest: compounds 2 and 3 (each within the scatter of the next); then compound 1.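

In this assay, among the compounds shown here, this is the first pair of compounds that differ in only one place, so it gives the first direct look at what a single swap at this position does: fluoro in place of trifluoromethyl gives a 1.3-fold higher number from compound 2 to compound 3 (0.11 log units; within the scatter). The position is an aromatic carbon of a six-membered aromatic ring of carbon only, para to a large group, and here a substituent of 4 heavy atoms can give way to one of 1 heavy atom without a change that stands out from ordinary repeat variation. Nothing available explains why the two readings stay so close, so the result describes what happens but gives no reason for it.

This is a single step between two halogen-bearing groups, so it cannot show whether the position tolerates changes in general. An amine, a carboxylic acid or a longer carbon chain at the same place could give a similar reading or a very different one, and the compounds shown do not settle which.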